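The compounds below may be only part of what the source reports. "The series", "measured", "known", "first", "only" and "open" are said of these compounds alone.

Values in an ADME assay on cells (Macrophage, Mus musculus) for cytotoxicity, read by resazurin assay, with a stated time of 3 days; a lower number here means a stronger inhibitor, a higher number a weaker inhibitor:
- compound 1 `O=C(Nc1cc(C(F)(F)F)cc(C(F)(F)F)c1)c1ccccc1O`: 12000 nM
- compound 2 `O=C(Nc1cc(C(F)(F)F)cc(C(F)(F)F)c1)c1cc(F)ccc1O`: 2500 nM
- compound 3 `O=C(Nc1cc(C(F)(F)F)cc(C(F)(F)F)c1)c1cc(Br)ccc1O`: 4900 nM
- compound 4 `COc1ccc(O)c(C(=O)Nc2cc(C(F)(F)F)cc(C(F)(F)F)c2)c1`: not yet measured

The standing of compound 3 rests on two steps: a 2.0-fold higher number from compound 2 to compound 3 (0.29 log units; within the scatter) and a 2.4-fold lower number from compound 1 to compound 3 (0.39 log units; beyond the scatter). The next change is methoxy in place of bromo on an aromatic carbon. The closest evidence is a 4.8-fold lower number from compound 1 to compound 2 (0.68 log units; beyond the scatter), alongside the same bromo step from the parent. Both steps are modest and go to lower numbers. Among the compounds with values here, no methoxy compound has been measured, so the series gives no direct reading for this group. The expected step is a 1.1-fold lower number from compound 3 to compound 4 (0.04 log units; within the scatter), with no change beyond the scatter. Compound 4 is estimated at 4500 nM, with an expected range of 1900 nM to 10500 nM.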

Compound 4, half-maximal inhibitory concentration: 7700 nM
For compound 4 the middle estimate is 1.7-fold (0.23 log units) below the measured one; measured number inside the range.
By their numbers in this assay, from the lowest: compounds 2, 3, 4 and 1 (each within the scatter of the next, the first and the last beyond it).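

In this assay, methoxy on this carbon, para to a hydroxy group, separates clearly only from fluoro, with a 3.1-fold higher number from compound 2 to compound 4 (0.49 log units; beyond the scatter) standing beyond the scatter. Against bromo and hydrogen it stays within the scatter, with a 1.6-fold higher number from compound 3 to compound 4 (0.20 log units; within the scatter) and a 1.6-fold lower number from compound 1 to compound 4 (0.19 log units; within the scatter) as the two steps, so a substituent here need not shift the number from the parent as fluoro and bromo do. Nothing available on these compounds bears on the reason. Open, as far as these compounds go, is whether an amine, a carboxylic acid or a longer chain such as ethoxy on this carbon would fall with fluoro or with hydrogen.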